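Adding a second phenylpropyl arm to a cyclohexane amino alcohol

The compounds below may be only part of what the source reports. "The series", "measured", "known", "first", "only" and "open" are said of these compounds alone.

The measured compounds:
compound 1, `CN(C)[C@H]1CCCC[C@@H]1OCCCc1ccccc1`, 4.6 nM
compound 2, `CN(C)[C@H]1CCCC[C@@H]1OC/C=C/c1ccccc1`, 59 nM
compound 3, `CN(CCCc1ccccc1)[C@H]1CCCC[C@@H]1O`, 19 nM

In an assay on brain for displacement of a labelled ligand from Sigma non-opioid intracellular receptor 1 (Rattus norvegicus), read by scintillation counting, with a stated time of 120 min (a lower number here means a stronger inhibitor, a higher number a weaker inhibitor), compound 3 gives 19 nM, the second highest of the three numbers; compound 2 sits above it and compound 1 below it, both gaps beyond the usual scatter. Compound 4, `CN(CCCc1ccccc1)[C@H]1CCCC[C@@H]1OCCCc1ccccc1`, carries 3-phenylpropyl in place of hydrogen on an oxygen on a saturated carbon. Compound 1 already shows that a phenylpropyl group on that oxygen can go with a low number, since compound 1 gives 4.6 nM. For compound 4 the number is therefore expected to fall somewhat, by a step from compound 3 of a 1.9-fold lower number from compound 3 to compound 4 (0.28 log units; within the scatter), a small move that may stay within the scatter. Compound 4 is estimated at 10 nM, with a range from 2 nM to 50 nM.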

Compound 4, inhibition constant: 790 nM
Beside the measured number, compound 4's estimate is 79-fold (1.90 log units) below it; the whole stated range lies below it.
By their numbers in this assay, from the lowest: compound 1; then compound 3; then compound 2; then compound 4.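

In this assay the two phenylpropyl arms do not add up: 3-phenylpropyl in place of hydrogen on the oxygen brings a 42-fold higher number from compound 3 to compound 4 (1.62 log units; beyond the scatter) as a large loss, and phenethyl in place of hydrogen on the saturated chain carbon bound to the amine nitrogen brings a 170-fold higher number from compound 1 to compound 4 (2.23 log units; beyond the scatter) as another. So the low number of compound 1 does not carry over, and what this oxygen tolerates depends on what the nitrogen carries. Nothing measured here explains the loss.

From the compounds shown here alone, whether a shorter arm on the oxygen, such as benzyl, would keep a low number alongside the nitrogen's 3-phenylpropyl stays open.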